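The source may hold more compounds than are shown below. What is called first, only, known or untested is meant among the compounds shown, and "the series" means these compounds.

For the measured compounds named here, compound 1, `COc1ccccc1-c1cc(CN(C)C)ccc1Cl`, is the one compound of this set for which a single number stands in an assay on HEK293 cells for displacement of a labelled ligand from 5-hydroxytryptamine receptor 7 (Homo sapiens), read by scintillation counting, with a stated time of 1.5 h; on this read-out lower numbers stand for stronger inhibition and higher numbers for weaker inhibition: it gives 20 nM, while its two further entries in this assay carry no single number. Beside it sit two secondary amines on the same core. Compound 2, `CCNCc1ccc(Cl)c(-c2ccccc2OC)c1`, gives 10 nM; 9.3 nM (2 entries) in this assay, with the repeated entries agreeing closely (the several entries of compound 2 in this assay, 10 nM; 9.3 nM (2 entries)). Compound 3, `CCCCNCc1ccc(Cl)c(-c2ccccc2OC)c1`, gives 52.5 nM; 52 nM (2 entries), again consistent across entries (the several entries of compound 3 in this assay, 52.5 nM; 52 nM (2 entries)), a higher number than compound 2 shows. Compound 4, `CCCN(CCC)Cc1ccc(Cl)c(-c2ccccc2OC)c1`, has not yet been measured. It differs from compound 1 by dipropylamino in place of dimethylamino on a saturated chain carbon bound to an aromatic carbon. Going by the values given here, no directly comparable step is available, so the size of the change in this assay is a matter of expectation. The larger secondary amine, compound 3, gives 52.5 nM; 52 nM (2 entries), so a weaker result is expected for compound 4 because compound 3 gives 52.5 nM; 52 nM (2 entries) where the smaller compound 2 gives 10 nM; 9.3 nM (2 entries). Compound 4 is therefore estimated at 60 nM, within a range of 20 nM to 200 nM, which is a step of a 3.0-fold higher number from compound 1 to compound 4 (0.48 log units; beyond the scatter) expected.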

Compound 4, inhibition constant: > 10000 nM
Compound 4: no number, only a limit; the forecaster's own chance of this, stated with the estimate: 5%; middle value at least 160-fold (2.22 log units) from the limit.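

In this assay compound 4 gives > 10000 nM, which is a limit of the assay and not a number: the limit of > 10000 nM in this assay, at which 1 of the 4 values shown sits. Dipropylamino in place of dimethylamino on a saturated chain carbon bound to an aromatic carbon thus brings an at least 500-fold higher number from compound 1 to compound 4 (2.69 log units; beyond the scatter), a large step from a single change. Compound 1, compound 2 and compound 3 all show numbers in this assay, and only compound 4 shows that a change at this place can carry a compound out to the limit of the read-out.

On these data alone, how far the true value of compound 4 lies past the limit stays unknown, so the full size of the step cannot be read. As far as these compounds go, whether diethylamino at this place would still give a number, or the loss already appears with it, also stays open.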